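Alkenyl amides: the step to compound 4

This account rests on a few compounds, and the source may have more. Where it says the series, first, only, none or still open, it means among the compounds named here.

In a functional assay on A549 cells (Homo sapiens) for antiproliferative activity, read by MTT assay, with a stated time of 72 h (on this read-out lower numbers stand for stronger inhibition and higher numbers for weaker inhibition), compound 1 `COc1cc(N(C)CCN(C)C)c(NC(=O)C(Cl)=C(Cl)Cl)cc1Nc1nccc(-c2cn(C)c3ccccc23)n1` gives > 50000 nM, which is a limit of the assay and not a number. Compound 2 `C/C=C\C(=O)Nc1cc(Nc2nccc(-c3cn(C)c4ccccc34)n2)c(OC)cc1N(C)CCN(C)C` gives 660 nM. Compound 3 `COc1cc(N(C)CCN(C)C)c(NC(=O)C=C(C)C)cc1Nc1nccc(-c2cn(C)c3ccccc23)n1` gives 4100 nM, the higher of the two actual numbers in the series.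

Compound 4 `CC/C=C\C(=O)Nc1cc(Nc2nccc(-c3cn(C)c4ccccc34)n2)c(OC)cc1N(C)CCN(C)C` differs from compound 3 as follows: but-1-en-1-yl in place of 2-methylprop-1-en-1-yl on a carbonyl carbon. In words, this is but-1-en-1-yl in place of 2-methylprop-1-en-1-yl on a carbonyl carbon.

Three measured steps change this same place. The two that start from the trichloroethenyl amide are large: an at least 75-fold lower number from compound 1 to compound 2 (1.87 log units; beyond the scatter) and an at least 12-fold lower number from compound 1 to compound 3 (1.08 log units; beyond the scatter). They say little here, as both rest on a limit. The closest guide is the modest 6.2-fold higher number from compound 2 to compound 3 (0.79 log units; beyond the scatter), which ends in the group that compound 4 gives up. By name, but-1-en-1-yl stands nearer to the prop-1-en-1-yl of compound 2, so a modest move to a lower number is expected in this assay. The expected change is a 2.7-fold lower number from compound 3 to compound 4 (0.44 log units; beyond the scatter). Compound 4 is estimated at 1500 nM, with an expected range of 500 nM to 4500 nM.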

Compound 4, half-maximal inhibitory concentration: 1530 nM
For compound 4 the middle estimate is 1.0-fold (0.01 log units) below the measured one; the measured number falls inside the stated range.
By their numbers in this assay, from the lowest: compound 2; then compound 4; then compound 3. At a limit, above all of these: compound 1.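

In this assay, but-1-en-1-yl in place of 2-methylprop-1-en-1-yl gives a 2.7-fold lower number from compound 3 to compound 4 (0.43 log units; beyond the scatter), so among these isomeric amides the arrangement of the alkenyl carbons alone shifts the number beyond the scatter. Extending prop-1-en-1-yl to but-1-en-1-yl gives a 2.3-fold higher number from compound 2 to compound 4 (0.37 log units; beyond the scatter), which places the linear homologue on the weaker side of compound 2 and shows that the added methyl is not neutral in this series. The step of an at least 32-fold lower number from compound 1 to compound 4 (1.51 log units; beyond the scatter) rests on the limit of compound 1 and gives only a bound: the limit of > 50000 nM in this assay, at which 1 of the 4 values shown sits.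

On these data alone, how the number responds to the unsubstituted ethenyl amide, or to a longer chain such as pent-1-en-1-yl, remains open. The same holds for a dimethylamino group at the end of the but-1-en-1-yl chain.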